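The source may report more compounds than this note shows. Statements on the series, on what has been measured and on what is new or still open speak of the compounds shown alone.

Compound 1 `CCOc1nc2ccccn2c(=N)c1S(=O)(=O)c1ccccc1` was measured in an assay on HeLa cells for displacement of a labelled ligand from 5-hydroxytryptamine receptor 6 (Homo sapiens) (on this read-out higher numbers stand for weaker inhibition and lower numbers for stronger inhibition), where compound 1 gives 12 nM. Among the three numbers known so far, that of compound 1 is the second highest. Its nearest neighbour is compound 2 `CSc1nc2ccccn2c(=N)c1S(=O)(=O)c1ccccc1Cl`, which in this assay gives 11 nM; the two values lie within the scatter of each other. The furthest is compound 3 `CSc1nc2ccccn2c(=N)c1S(=O)(=O)c1ccc2ccccc2c1`, which in this assay gives 59 nM, a number beyond the scatter from that of compound 1. Compound 4 `C[S+]([O-])c1nc2ccccn2c(=N)c1S(=O)(=O)c1ccccc1` has not yet been measured. It differs from compound 1 in one place: a group of 3 heavy atoms (1 carbon, 1 oxygen, 1 sulfur; no ring) in place of a group of 3 heavy atoms (2 carbon, 1 oxygen; no ring), on an aromatic carbon, next to the ring nitrogen. For the measured compounds named here, no measured pair shows this exact change, so its effect in this assay is unknown, and compounds 2 and 3 carry other groups there and elsewhere, offering no direct guide. A small step is expected, probably toward a somewhat higher number, though it may stay within the scatter. For compound 4 this means an expected 2.1-fold higher number from compound 1 to compound 4 (0.32 log units; beyond the scatter). Compound 4 is estimated at 25 nM, within a range from 8 nM to 80 nM.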

Compound 4, half-maximal inhibitory concentration: 250 nM
Compound 4: middle estimate off by 10-fold (1.00 log units), on the low side, and the stated range ends below it.
By their numbers in this assay, from the lowest: compounds 2 and 1 (each within the scatter of the next); then compound 3; then compound 4.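

In this assay, the exchange of the ethoxy group on this aromatic carbon for the group of 3 heavy atoms containing sulfur gives a 21-fold higher number from compound 1 to compound 4 (1.32 log units; beyond the scatter), a large step. The position is therefore not indifferent to what stands on it: the two groups match in heavy-atom count, in having no ring, in their counted hydrogen-bond donors and acceptors and in net charge, so these counts alone do not set the value here. Nothing at hand accounts for the size of this step.

The compounds shown leave open how an amine or a longer chain such as butoxy would read at this position. They also leave open whether the same exchange would give a step of similar size with a different group on the sulfonyl.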